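The compounds below may be only part of what the source reports. "The series", "measured", "known", "first", "only" and "open" are said of these compounds alone.

Three compounds built on one shared core were tested in an ADME assay on Akata cells (Homo sapiens) for cytotoxicity, with a stated time of 7 days; on this read-out higher numbers stand for lower toxicity in this test and lower numbers for higher toxicity in this test. Compound 1, `CCCOc1nc(N)nc2c1ncn2/C=C1/CC1(CO)CO`, gives in this assay only a limit, > 20000 nM. Compound 2, `CCCCNc1nc(N)nc2c1ncn2/C=C1/CC1(CO)CO`, likewise gives in this assay a limit, > 24000 nM. Compound 3, `CSc1nc(N)nc2c1ncn2/C=C1/CC1(CO)CO`, also stops at a limit in this assay, > 20000 nM. Because two of the three values sit at the limit of > 20000 nM in this assay, at which 2 of the 3 values shown sit, and the third at the limit of > 24000 nM in this assay, at which 1 of the 3 values shown sits, none of the steps between these compounds can be sized: a step that the two limits leave unreadable from compound 1 to compound 2, a step that the two limits leave unreadable from compound 1 to compound 3 and a step that the two limits leave unreadable from compound 2 to compound 3 all remain unreadable. Compound 3 therefore stands where its two companions stand, at a limit with nothing to set it apart from them.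

Compound 4, `C=CCOc1nc(N)nc2c1ncn2/C=C1/CC1(CO)CO`, differs from compound 3 by allyloxy in place of methylsulfanyl on an aromatic carbon. Going by the values given here, no measured step bears directly on this change, and the steps that were measured could not be sized, so no step beyond the scatter can be expected in either direction in this assay. Compound 4 is accordingly expected to sit again near or past the limit in this assay, with an estimate of 30000 nM and a range from 12000 nM to 100000 nM. The implied step is estimated as a step that the limit leaves unreadable from compound 3 to compound 4.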

Compound 4, half-maximal cytotoxic concentration: > 20000 nM
Compound 4: no number, only a limit; the forecaster's own chance of this, stated with the estimate: 85%; the middle value lies beyond the limit too.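

In this assay compound 4 gives > 20000 nM as a limit and not a number, and none of the steps from compound 1, compound 2 or compound 3 to compound 4 can be read. The compounds shown leave open where each true cytotoxic concentration lies, and whether swapping these groups on the shared core changes it at all.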